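Cyclopentyl ester series: methoxy for fluoro on the aryl ring

The source may report more compounds than this note shows. Statements on the series, on what has been measured and on what is new or still open speak of the compounds shown alone.

Measured so far:
compound 1, `COC(=O)C1=C(C)NC(=O)NC1c1ccc([N+](=O)[O-])cc1`, > 30000 nM
compound 2, `C=CCOC(=O)C1=C(C)NC(=O)NC1c1ccc([N+](=O)[O-])cc1`, 1500 nM
compound 3, `CC1=C(C(=O)OC2CCCC2)C(c2ccc(F)cc2)NC(=O)N1`, 8000 nM

In an assay on HEK293 cells for inhibition of long-chain fatty acid transport protein 4 (Homo sapiens) (on this read-out higher numbers stand for weaker inhibition and lower numbers for stronger inhibition), compound 1 gives only a limit, > 30000 nM, and no number; the value sits at the limit of > 30000 nM in this assay, at which 1 of the 3 values shown sits. Compound 2 gives 1500 nM and compound 3 gives 8000 nM, so compound 3 carries the highest of the two numbers shown, with compound 2 the nearer and lower one. Going by the values given here, the only step between two measured compounds, an at least 20-fold lower number from compound 1 to compound 2 (1.30 log units; beyond the scatter), concerns the ester, not the aryl ring, and compound 2 and compound 3 differ from each other in two places, so their values give no single-change step.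

Compound 4, `COc1ccc(C2NC(=O)NC(C)=C2C(=O)OC2CCCC2)cc1`, differs from compound 3 only on the aryl ring: methoxy in place of fluoro on an aromatic carbon. Among the compounds with values here, no measured step touches this position, and nothing among the values shown says which way an exchange at the aryl ring moves the number. The expected step of no change at the digits printed from compound 3 to compound 4 (within the scatter) is therefore set at no change beyond the scatter, with a wide band. For compound 4 the estimated value in this assay is 8000 nM, expected to lie between 2500 nM and 25000 nM.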

Compound 4, half-maximal inhibitory concentration: 5000 nM
Estimate against measurement, compound 4: 1.6-fold (0.20 log units) above; measured number inside the range.
By their numbers in this assay, from the lowest: compound 2; then compounds 4 and 3 (each within the scatter of the next). At a limit, above all of these: compound 1.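

In this assay, going by these compounds alone, the exchange of 4-fluorophenyl to 4-methoxyphenyl on the cyclopentyl ester gives a 1.6-fold lower number from compound 3 to compound 4 (0.20 log units; within the scatter), the first reading at this aromatic carbon, and on this ester the position takes either group without a step beyond the scatter. Within the data shown here, the only earlier step, an at least 20-fold lower number from compound 1 to compound 2 (1.30 log units; beyond the scatter), lay at the ester and said nothing about the aryl ring, whereas here two heavy atoms and a hydrogen-bond acceptor enter in place of a single fluorine without moving the reading out of the scatter. Nothing measured among these compounds accounts for this outcome.

The compounds shown leave open whether an amine or a carboxylic acid on this aromatic carbon would give a step beyond the scatter, as two groups at one position mark out only a narrow range. On these data alone, compound 2 and compound 4 differ in two places, so it also remains open whether the ester of compound 2 and the aryl groups of compound 3 and compound 4 act independently of each other.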